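The source may hold more compounds than are shown below. What is called first, only, known or untested is meant among the compounds shown, and "the series" means these compounds.

In a functional assay on KB-VIN10 cells (Homo sapiens) for inhibition, with a stated time of 72 h (on this read-out higher numbers stand for weaker inhibition and lower numbers for stronger inhibition), compound 2 (`COc1ccc(S(=O)(=O)N2CCc3cccc(-c4cccnc4)c32)cc1`) gives 84.5 nM and compound 1 (`COc1ccc(S(=O)(=O)N2CCc3cccc(-c4ccc([N+](=O)[O-])cc4)c32)cc1`) gives 51.3 nM, so the two stand within the scatter of each other. Compound 3 (`COc1ccc(S(=O)(=O)N2CCc3cccc(-c4ccc(C#N)cc4)c32)cc1`) carries 4-cyanophenyl in place of pyridin-3-yl on an aromatic carbon. Among the measured compounds shown here, the one measured step that bears on this change, which put pyridin-3-yl in place of 4-nitrophenyl on an aromatic carbon, is a 1.6-fold higher number from compound 1 to compound 2 (0.22 log units; within the scatter). Since that step stayed within the scatter, no step beyond the scatter is expected here, and the estimated step is a 1.4-fold lower number from compound 2 to compound 3 (0.15 log units; within the scatter). Compound 3 is estimated at 60 nM, with an expected range of 25 nM to 150 nM.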

Compound 3, half-maximal inhibitory concentration: 29.2 nM
Beside the measured number, compound 3's estimate is 2.1-fold (0.31 log units) above it, and the stated range covers the measured number.
By their numbers in this assay, from the lowest: compounds 3, 1 and 2 (each within the scatter of the next, the first and the last beyond it).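

In this assay, this position on the aromatic carbon now shows its first step beyond the scatter: 4-cyanophenyl in place of pyridin-3-yl gives a modest change (a 2.9-fold lower number from compound 2 to compound 3 (0.46 log units; beyond the scatter)). Cyano in place of nitro on the phenyl ring, by contrast, stays within the scatter (a 1.8-fold lower number from compound 1 to compound 3 (0.24 log units; within the scatter)), so compound 1 and compound 3 are not told apart. Nothing shown here accounts for the step from pyridin-3-yl. Open, on these data alone, is how a plain phenyl, or a phenyl ring carrying an amine or a carboxylic acid, would stand against these compounds.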